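Trifluoromethyl for chloro on the urea aryl of compound 1

The source may hold more compounds than are shown below. What is called first, only, known or untested is meant among the compounds shown, and "the series" means these compounds.

For the measured compounds named here, compound 1 `COc1cc(-c2nn(-c3cccc(NC(=O)Nc4ccc(Cl)c(Cl)c4)c3)cc2-c2ccncc2)ccc1Cl` gives 932 nM in a functional assay on SR cells (Homo sapiens) for inhibition, read by sulforhodamine B assay, with a stated time of 48 h (a higher number here means a weaker inhibitor of growth, a lower number a stronger inhibitor of growth), the second highest of the three numbers measured so far. Compound 2 `O=C(Nc1cccc(-n2cc(-c3ccncc3)c(-c3ccc(Cl)c(O)c3)n2)c1)Nc1ccc(Cl)c(Cl)c1` gives 1140 nM and compound 3 `O=C(Nc1cccc(-n2cc(-c3ccncc3)c(-c3ccc(Cl)c(O)c3)n2)c1)Nc1cc(C(F)(F)F)cc(C(F)(F)F)c1` gives 922 nM; both lie within the scatter of compound 1. Going by the values given here, the only neighbouring step, a 1.2-fold higher number from compound 1 to compound 2 (0.09 log units; within the scatter), changes almost nothing. Compound 4 `COc1cc(-c2nn(-c3cccc(NC(=O)Nc4ccc(Cl)c(C(F)(F)F)c4)c3)cc2-c2ccncc2)ccc1Cl` differs from compound 1 by trifluoromethyl in place of chloro on an aromatic carbon. Among the compounds with values here, no measured step covers this exchange; compound 3, which carries two trifluoromethyl groups on that ring, merely shows a value close to compound 1. Compound 4 is therefore expected to move by a 1.0-fold lower number from compound 1 to compound 4 (0.02 log units; within the scatter), not beyond the scatter. The estimate for compound 4 is 900 nM, with a range of 400 nM to 2000 nM.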

Compound 4, concentration for 50% growth inhibition: 884 nM
Compound 4: the middle estimate sits 1.0-fold (0.01 log units) above what was measured; the range from low to high includes it.
By their numbers in this assay, from the lowest: compounds 4, 3, 1 and 2 (each within the scatter of the next).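

In this assay, for the compounds shown here, trifluoromethyl in place of chloro, ortho to a chloro group, gives a 1.1-fold lower number from compound 1 to compound 4 (0.02 log units; within the scatter) and is the first single exchange read at this position. Going by these compounds alone, the position thus takes a group of 4 heavy atoms in place of 1 with a step within the scatter, which no earlier step could show. Nothing available accounts for this result.

Going by these compounds, whether an amine, a carboxylic acid or a longer chain at this position would also stay within the scatter remains open. So does the effect of changing the remaining chloro group on that ring.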